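The source may report more compounds than this note shows. Statements on the series, on what has been measured and on what is new or still open speak of the compounds shown alone.

Compound 1, with structure `Cc1c(C(=O)CSCCNC(=O)c2ccccc2)[n+]([O-])c2ccccc2[n+]1[O-]`, carries a benzoyl amide on the side chain of the shared core. In an ADME assay on Vero cells (Chlorocebus sabaeus) for cytotoxicity, read by MTT assay, with a stated time of 72 h (a lower number here means that less compound is tolerated, a higher number that more compound is tolerated), compound 1 gives > 100 ug/mL, which is a limit of the assay and not a number. That reading sits at the limit of > 100 ug/mL in this assay, at which 1 of the 2 values shown sits. Compound 2, with structure `Cc1c(C(=O)CSCCNC(=O)C2CCCCC2)[n+]([O-])c2ccccc2[n+]1[O-]`, bears a cyclohexyl group on the carbonyl carbon instead; for compound 2 the outcome in this assay is "not determined" (no result reported), so no number is known for it. Compound 3, with structure `Cc1c(C(=O)CSCCNC(=O)c2ccc3ccccc3c2)[n+]([O-])c2ccccc2[n+]1[O-]`, differs from compound 2 by naphthalen-2-yl in place of cyclohexyl on a carbonyl carbon. Within the data shown here, with only a limit for compound 1 and nothing for compound 2, no step in this assay can be sized; the expectation is that the change from compound 2 to compound 3 moves this assay by no more than the usual scatter. For compound 3 the estimated value in this assay is 100 ug/mL, with a range from 30 ug/mL to 300 ug/mL.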

Compound 3, half-maximal cytotoxic concentration: > 100 ug/mL
Compound 3 gave a limit, no number; the forecaster's own chance of this, stated with the estimate: 60%; the middle value sits exactly at the limit.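

In this assay compound 3 gives > 100 ug/mL, a limit and not a number. Compound 1 also stands at a limit, so no step can be read between compound 1 and compound 3: the limit of > 100 ug/mL in this assay, at which 2 of the 3 values shown sit. The compounds shown leave open how compound 1, compound 2 and compound 3 would compare on actual numbers in this assay.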